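The compounds below may be only part of what the source reports. "The series", "measured", "known", "first", "only" and "open" are said of these compounds alone.

Compound 2 `CC(C)c1nc(C(C)(C)C)cc(-c2ccc(F)cc2)c1/C=C/[C@@H]1C[C@@H](O)CC(=O)O1` has the lowest number of the two measured compounds in an assay for inhibition of 3-hydroxy-3-methylglutaryl-coenzyme A reductase (Rattus norvegicus); on this read-out lower numbers stand for stronger inhibition and higher numbers for weaker inhibition: compound 2 gives 1 nM, while compound 1 `Cc1cc(-c2ccc(F)cc2)c(/C=C/[C@@H]2C[C@@H](O)CC(=O)O2)c(C(C)C)n1` gives 9 nM in this assay. Going by the values given here, the one step measured so far, a 9.0-fold lower number from compound 1 to compound 2 (0.95 log units; beyond the scatter), shows that enlarging the alkyl group on the aromatic carbon of the shared core lowers the number clearly. Compound 3 `CC(C)c1nc(C2CCCCC2)cc(-c2ccc(F)cc2)c1/C=C/[C@@H]1C[C@@H](O)CC(=O)O1` carries the change (cyclohexyl in place of tert-butyl on an aromatic carbon). Among the compounds with values here, no measured pair shows what a ring in place of a branched chain at this position does, so the only guide is the step from compound 1 to compound 2, which favours a larger group. A further gain beyond the scatter is not expected, since compound 2 already stands at 1 nM; the expected step is a 2.0-fold higher number from compound 2 to compound 3 (0.30 log units; within the scatter) in this assay. The estimate for compound 3 in this assay is 2 nM, expected to fall between 0.5 nM and 8 nM.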

Compound 3, half-maximal inhibitory concentration: 4 nM
Compound 3: middle estimate off by 2.0-fold (0.30 log units), on the low side, within the range that was stated.
By their numbers in this assay, from the lowest: compound 2; then compound 3; then compound 1.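

In this assay, the gain seen on going from methyl to tert-butyl does not continue with the larger cyclohexyl group: there is a 4.0-fold higher number from compound 2 to compound 3 (0.60 log units; beyond the scatter). Cyclohexyl still improves on methyl, with a 2.3-fold lower number from compound 1 to compound 3 (0.35 log units; beyond the scatter), so at this position, on the aromatic carbon next to the ring nitrogen, the lowest number belongs to tert-butyl and not to the group with the most heavy atoms. No measurement offered here explains why the ring falls short of the branched chain.

The three compounds leave open where a smaller ring such as cyclopropyl, an unbranched chain such as n-butyl, or an aromatic phenyl ring would fall in this order. They also do not show how a group containing oxygen or nitrogen, such as methoxy or an amine, would behave at this position.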